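Chain-extended amide analogues on a dioxolane cytosine core

The compounds below may be only part of what the source reports. "The series", "measured", "known", "first", "only" and "open" are said of these compounds alone.

Measured so far:
compound 1 `CCCC(=O)Nc1ccn([C@@H]2CO[C@H](CO)O2)c(=O)n1` — 6600 nM
compound 2 `CCCCC(=O)Nc1ccn([C@@H]2CO[C@H](CO)O2)c(=O)n1` — 5230 nM
compound 3 `CCCCCCCCCC(=O)Nc1ccn([C@@H]2CO[C@H](CO)O2)c(=O)n1` — 24 nM

In a functional assay on A549 cells (Homo sapiens) for cytotoxicity, read by sulforhodamine B assay, with a stated time of 72 h (on this read-out higher numbers stand for weaker inhibition and lower numbers for stronger inhibition), compound 3 holds the lowest number of the three, with compound 2 nearest at a 220-fold lower number from compound 2 to compound 3 (2.34 log units; beyond the scatter) and compound 1 furthest at a 280-fold lower number from compound 1 to compound 3 (2.44 log units; beyond the scatter). Compound 4 `CCCCCCCCCCCCCCCCCC(=O)Nc1ccn([C@@H]2CO[C@H](CO)O2)c(=O)n1` carries octyl in place of hydrogen on a saturated chain carbon, nine bonds along the chain from a carbonyl carbon. Among the compounds with values here, both large steps so far came from lengthening the same chain, whereas a 1.3-fold lower number from compound 1 to compound 2 (0.10 log units; within the scatter) was a small extension and stayed within the scatter. Within the data shown here, no measured step adds a chain of this length at this distance from the carbonyl, so the large gains seen from compound 1 and compound 2 to compound 3 cannot simply be carried forward. The expected outcome is a modest further lowering or no change, a 1.3-fold higher number from compound 3 to compound 4 (0.10 log units; within the scatter), with a wide range. For compound 4 the estimate in this assay is 30 nM, between 4 nM and 400 nM.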

Compound 4, half-maximal inhibitory concentration: 25 nM
The estimate for compound 4 lay 1.2-fold (0.08 log units) above the measured number, and the stated range covers the measured number.
By their numbers in this assay, from the lowest: compounds 3 and 4 (each within the scatter of the next); then compounds 2 and 1 (each within the scatter of the next).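

In this assay, octyl in place of hydrogen on a saturated chain carbon, nine bonds along the chain from a carbonyl carbon, gives a 1.0-fold higher number from compound 3 to compound 4 (0.02 log units; within the scatter), so at this position the chain of compound 3 accepts this further length with no separation from compound 3. The large steps from compound 1 and compound 2 therefore do not extend to this change. No evidence on the reason for this result is at hand.

Open, from the compounds shown here alone, is which chain length short of compound 3 carries the large step. Also open, going by these compounds, is how a longer chain, an amine or a carboxylic acid in place of octyl would read.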